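This account rests on a few compounds, and the source may have more. Where it says the series, first, only, none or still open, it means among the compounds named here.

Measured compounds:
compound 1, `O=C(CC(=O)c1ccccc1O)c1cc2ccccc2s1`: > 100 ug/mL
compound 2, `Cc1ccc(O)c(C(=O)CC(=O)c2cc3ccccc3s2)c1`: > 100 ug/mL

The two measured compounds share one core and differ only by a methyl group. In an ADME assay on THP-1 cells (Homo sapiens) for inhibition, read by MTT assay, with a stated time of 72 h (a higher number here means a weaker inhibitor of growth, a lower number a stronger inhibitor of growth), compound 1 gives > 100 ug/mL. That value is a limit of the assay, not a number. Compound 2 gives > 100 ug/mL in this assay. This, too, is a limit of the assay. Going by the values given here, compound 1 thus stands only at a limit, and the one other value shown beside it is a limit as well; the whole evidence here is the limit of > 100 ug/mL in this assay, at which 2 of the 2 values shown sit. The step that the two limits leave unreadable from compound 1 to compound 2 cannot be read, since both of its ends are limits.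

Compound 3 is `Cc1ccc(C(=O)CC(=O)c2cc3ccccc3s2)c(O)c1`. It differs from compound 1 in one place: methyl in place of hydrogen on an aromatic carbon. Among the compounds with values here, the only measured step that bears on this kind of change is a step that the two limits leave unreadable from compound 1 to compound 2, and it gives no readable size, so there is no measured basis for a step of any size in either direction in this assay. The expected step that the limit leaves unreadable from compound 1 to compound 3 is therefore none beyond the scatter. Compound 3 is expected to come out at 150 ug/mL in this assay, within 100 ug/mL to 300 ug/mL, most likely again as a limit.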

Compound 3, concentration for 50% growth inhibition: > 100 ug/mL
Compound 3: no number, only a limit; the forecaster's own chance of this, stated with the estimate: 90%; the middle value is on the limit's open side.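

In this assay, going by these compounds alone, compound 3 gives > 100 ug/mL, which is a limit of the assay and not a number, so no step from compound 1 to compound 3 can be read. The compounds shown leave open whether the methyl group in compound 2 or compound 3 changes growth inhibition at all, as the whole evidence is a single limit: the limit of > 100 ug/mL in this assay, at which 3 of the 3 values shown sit.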